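Triazole in Place of Pyrrolidinone: Expected Cytotoxicity of Compound 4

The source may hold more compounds than are shown below. What is called first, only, known or untested is meant among the compounds shown, and "the series" means these compounds.

Measured so far in an ADME assay on MT2 cells (Homo sapiens) for cytotoxicity; on this read-out higher numbers stand for lower toxicity in this test and lower numbers for higher toxicity in this test:
Compound 1 `CCc1cc(CNC(=O)c2cc3nc(C)c([C@H](OC(C)(C)C)C(=O)O)c(-c4cc(F)c5c(c4C)CCCO5)n3n2)ccc1F` gives > 40000 nM, which is a limit of the assay.
Compound 2 `COc1cc(CNC(=O)c2cc3nc(C)c([C@H](OC(C)(C)C)C(=O)O)c(-c4cc(F)c5c(c4C)CCCO5)n3n2)ccc1F` gives > 20000 nM, which is a limit of the assay.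
Compound 3 `Cc1nc2cc(C(=O)NCc3ccc(F)cc3N3CCCC3=O)nn2c(-c2cc(F)c3c(c2C)CCCO3)c1[C@H](OC(C)(C)C)C(=O)O` gives > 40000 nM, which is a limit of the assay.

Compound 3 thus stands at the limit of > 40000 nM in this assay, at which 2 of the 3 values shown sit. Compound 4 `Cc1nc2cc(C(=O)NCc3ccc(F)cc3-n3cncn3)nn2c(-c2cc(F)c3c(c2C)CCCO3)c1[C@H](OC(C)(C)C)C(=O)O` differs from it by 1H-1,2,4-triazol-1-yl in place of 2-oxopyrrolidin-1-yl on an aromatic carbon. Within the data shown here, the only measured step, a step that the two limits leave unreadable from compound 1 to compound 2, concerns a different change, and its size is hidden by the two limits, so it offers no guide to the present change. Among the measured compounds shown here, with no measured step bearing on it, the step expected in this assay is a number no higher from compound 3 to compound 4 (the limit leaves the size open), which lies within the scatter. Compound 4 is estimated at 40000 nM, with a range from 20000 nM to 80000 nM, and most likely it will again be reported only as a limit.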

Compound 4, half-maximal cytotoxic concentration: > 40000 nM
Compound 4: only a limit was reported (the forecaster's own chance of this, stated with the estimate: 85%); the middle value lies on the limit itself.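

Among these compounds, compound 4, like compound 1, compound 2 and compound 3, is reported only as a limit in this assay, so no step to compound 4 can be read. The compounds shown leave open whether 1H-1,2,4-triazol-1-yl in place of 2-oxopyrrolidin-1-yl changes cytotoxicity at all.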